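Swapping a dichlorobenzyl for a benzyl on a biphenyl phenol

The source may hold more compounds than are shown below. What is called first, only, known or untested is meant among the compounds shown, and "the series" means these compounds.

Measured so far in a functional assay on CNE2Z cells (Homo sapiens) for inhibition, read by MTT assay, with a stated time of 72 h; on this read-out lower numbers stand for stronger inhibition and higher numbers for weaker inhibition:
compound 1 `C=CCc1ccc(O)c(-c2ccc(OCc3ccccc3)c(CC=C)c2)c1`: 30300 nM
compound 2 `C=CCc1ccc(O)c(-c2ccc(OCc3c(Cl)cccc3Cl)c(CC=C)c2)c1`: 16400 nM
compound 3 `C=CCc1ccc(OCc2c(Cl)cccc2Cl)c(-c2ccc(O)c(CC=C)c2)c1`: 19900 nM

Compound 2 and compound 3 are built from the same atoms joined differently; the difference between the two cores is not broken down here. Compound 1 differs from compound 2 by phenyl in place of 2,6-dichlorophenyl on a saturated chain carbon bound to an oxygen on an aromatic ring, and that change made a 1.8-fold higher number from compound 2 to compound 1 (0.27 log units; within the scatter). Compound 4 `C=CCc1ccc(OCc2ccccc2)c(-c2ccc(O)c(CC=C)c2)c1` has not yet been tested in this assay. It differs from compound 3 by phenyl in place of 2,6-dichlorophenyl on a saturated chain carbon bound to an oxygen on an aromatic ring, the same change at the same place as before. A step of about the same size is expected, a 1.7-fold higher number from compound 3 to compound 4 (0.22 log units; within the scatter), because the earlier step read a 1.8-fold higher number from compound 2 to compound 1 (0.27 log units; within the scatter) and compound 3 stands at 19900 nM. Compound 4 is therefore estimated at 33000 nM, most likely between 15000 nM and 75000 nM.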

Compound 4, half-maximal inhibitory concentration: 24000 nM
For compound 4 the middle estimate is 1.4-fold (0.14 log units) above the measured one; low and high end bracket the measured number.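

In this assay, putting phenyl in place of 2,6-dichlorophenyl gave a 1.2-fold higher number from compound 3 to compound 4 (0.08 log units; within the scatter), so on this second core the step again stays within the scatter. Set beside the earlier step, the two readings do not differ: the same change on two cores in this assay, a 1.8-fold higher number (0.27 log units; within the scatter) from compound 2 to compound 1 and a 1.2-fold higher number (0.08 log units; within the scatter) from compound 3 to compound 4, 1.5-fold (0.19 log units) apart, within the scatter of two such steps. The change therefore behaves alike on these two cores, but neither step is large enough to show that the change has a real effect of its own, and two cores say nothing about how it would behave on a third.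

The compounds shown carry only benzyl and 2,6-dichlorobenzyl on that oxygen. Going by these compounds, whether a different group there, such as a longer chain ending in an amine or a carboxylic acid, would shift the number beyond the scatter remains open.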